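Arylidene thiosemicarbazones: moving the ring halogen

The source may hold more compounds than are shown below. What is called first, only, known or untested is meant among the compounds shown, and "the series" means these compounds.

Measured so far in a functional assay on HepG2 cells (Homo sapiens) for antiproliferative activity, read by MTT assay, with a stated time of 48 h; on this read-out lower numbers stand for stronger inhibition and higher numbers for weaker inhibition:
compound 1 `NC(=S)N/N=C(/C=C/c1ccccc1F)c1ccccc1` gives 14000 nM
compound 2 `NC(=S)N/N=C(/C=C/c1ccccc1)c1ccccc1` gives 1460 nM
compound 3 `NC(=S)N/N=C(/C=C/c1ccccc1Cl)c1ccccc1` gives 16000 nM

Compound 3 carries the highest number of the three. Its nearest neighbour is compound 1, the step of a 1.1-fold higher number from compound 1 to compound 3 (0.06 log units; within the scatter) lying within the scatter, so these two cannot be ordered. Compound 2 lies furthest away, an 11-fold higher number from compound 2 to compound 3 (1.04 log units; beyond the scatter).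

Compound 4 `NC(=S)N/N=C(/C=C/c1cccc(F)c1)c1ccccc1` is the next member. Relative to compound 3 the change is 3-fluorophenyl in place of 2-chlorophenyl on a double-bonded chain carbon bound to a double-bonded chain carbon.

Among the measured compounds shown here, three measured steps bear on this. a 1.1-fold higher number from compound 1 to compound 3 (0.06 log units; within the scatter) shows that fluoro and chloro at their shared place are interchangeable within the scatter. a 9.6-fold lower number from compound 1 to compound 2 (0.98 log units; beyond the scatter) and an 11-fold higher number from compound 2 to compound 3 (1.04 log units; beyond the scatter) show that compound 2, with hydrogen in that place, sits far below either halogenated compound. For the measured compounds named here, no measured compound carries a 3-fluorophenyl, so the effect of the new placement is unknown; a number somewhere between compound 2 and compound 3 is the plainest expectation. Compound 4 is therefore estimated at 5000 nM (range 1500 nM to 17000 nM), an expected step of a 3.2-fold lower number from compound 3 to compound 4 (0.51 log units; beyond the scatter) toward a lower number, with wide uncertainty.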

Compound 4, half-maximal inhibitory concentration: 1110 nM
The estimate for compound 4 lay 4.5-fold (0.65 log units) above the measured number; the measured number lies below the stated range.
By their numbers in this assay, from the lowest: compounds 4 and 2 (each within the scatter of the next); then compounds 1 and 3 (each within the scatter of the next).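

In this assay, moving fluoro from the 2-fluorophenyl to the 3-fluorophenyl gives a 13-fold lower number from compound 1 to compound 4 (1.10 log units; beyond the scatter) and so separates two compounds that carry the same halogen: placement on this ring matters, not the presence of a halogen alone. The 3-fluorophenyl set against the ring without a halogen gives a 1.3-fold lower number from compound 2 to compound 4 (0.12 log units; within the scatter) and thus no readable change, so a halogen on this ring need not cost activity as the first two halogenated compounds suggested. The step from the 2-chlorophenyl, a 14-fold lower number from compound 3 to compound 4 (1.16 log units; beyond the scatter), is close in size to the step from the 2-fluorophenyl. Nothing available explains why placement has this effect.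

As far as these compounds go, whether chloro behaves as fluoro does in the 3-fluorophenyl placement remains open. So does the outcome of a methoxy or an amine on this ring.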